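Removing One Chloro From Compound 2

The compounds below may be only part of what the source reports. "The series", "measured", "known", "first", "only" and "open" are said of these compounds alone.

In a functional assay on HL-60 cells (Homo sapiens) for cytotoxicity, read by luminescence and CellTiter-Glo, with a stated time of 3 days (a higher number here means a weaker inhibitor, a lower number a stronger inhibitor), compound 1 `N#Cc1ccc2nc(-c3ccccc3O)[nH]c2c1` gives > 10000 nM, which is a limit and not a number. Among the measured compounds shown here, compound 2 `O=C(Nc1ccc(Cl)cc1Cl)c1ccc2cccnc2c1O` gives 610 nM, the only true number so far in this assay. Compound 3 `O=C(Nc1ccc(Cl)cc1)c1ccc2cccnc2c1O` differs in one place: hydrogen in place of chloro on an aromatic carbon, ortho to a large group. For the measured compounds named here, no measured pair yet shows what such a change does. The estimated 1.5-fold higher number from compound 2 to compound 3 (0.17 log units; within the scatter) is therefore small, toward weaker inhibition, and may stay within the usual scatter. For compound 3 the expected value is 900 nM, within an estimated range of 300 nM to 3000 nM.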

Compound 3, half-maximal inhibitory concentration: 630 nM
Beside the measured number, compound 3's estimate is 1.4-fold (0.15 log units) above it, and the stated range covers the measured number.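

Among the compounds shown here, the first measured pair at this position gives a 1.0-fold higher number from compound 2 to compound 3 (0.01 log units; within the scatter) in this assay when hydrogen takes the place of chloro on an aromatic carbon, ortho to a large group. The chloro at this place can therefore be removed with no change beyond the usual scatter, while the other chloro stays in both compounds. Nothing shown gives a measured reason for this result.

Still open, going by these compounds, is whether a different group at this place, such as a methoxy group or an amine, would move the number. The pair also cannot say what the remaining chloro contributes.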